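A sulfur-bearing tail in place of a hydroxyalkyl chain

The source may report more compounds than this note shows. Statements on the series, on what has been measured and on what is new or still open speak of the compounds shown alone.

Of the compounds shown here, three sharing one core have been tested in a functional assay on A549 cells (Homo sapiens) for inhibition, read by MTT assay, with a stated time of 72 h; on this read-out higher numbers stand for weaker inhibition and lower numbers for stronger inhibition. Compound 1 `O=c1cc(Cn2cc(C3CC3)nn2)c2ccc(O)cc2o1` gives 91700 nM in this assay. Compound 2 `CC(O)c1cn(Cc2cc(=O)oc3cc(O)ccc23)nn1`, bearing 1-hydroxyethyl in place of cyclopropyl, reaches only the limit of the assay, > 100000 nM. Compound 3 `O=c1cc(Cn2cc(CCCCO)nn2)c2ccc(O)cc2o1` likewise sits at the limit of the assay, > 100000 nM. The steps of an at least 1.0-fold higher number from compound 1 to compound 2 (0.03 log units; that floor lies within the scatter) and an at least 1.0-fold higher number from compound 1 to compound 3 (0.03 log units; that floor lies within the scatter) both end at that limit, (the limit of > 100000 nM in this assay, at which 2 of the 3 values shown sit), and the step that the two limits leave unreadable from compound 2 to compound 3 cannot be read. Among the compounds with values here, compound 3 thus stands at the weak end of what the numbers can show: two of the three values, its own among them, are limits, and no step among the three rises beyond the scatter.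

Compound 4 `O=c1cc(Cn2cc(CSC(=S)N3CCOCC3)nn2)c2ccc(O)cc2o1` differs from compound 3 by a group of 9 heavy atoms (5 carbon, 1 nitrogen, 1 oxygen, 2 sulfur; one six-membered non-aromatic ring with 2 hetero atoms) in place of a group of 4 heavy atoms (3 carbon, 1 oxygen; no ring), on a saturated chain carbon bound to an aromatic carbon. Within the data shown here, none of the measured steps touches this group; each of them exchanges a cyclopropyl for a hydroxyalkyl chain, and all stay within or at the floor of the scatter. Among the measured compounds shown here, no measured step therefore bears directly on the change from compound 3 to compound 4, and the expected step of an at least 1.6-fold lower number from compound 3 to compound 4 (0.22 log units; that floor lies within the scatter) rests on no anchor in the data. Compound 4 is expected to give about 60000 nM in this assay, within a range from 12000 nM to 150000 nM, with a fair chance that only a limit is reported again.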

Compound 4, half-maximal inhibitory concentration: 70200 nM
Beside the measured number, compound 4's estimate is 1.2-fold (0.07 log units) below it, and the stated range covers the measured number.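

Unlike the earlier steps, which exchange one group for another on an aromatic carbon, this change falls on a saturated chain carbon bound to an aromatic carbon, and it yields a measured number: in this assay compound 4 gives 70200 nM. The change reads as an at least 1.4-fold lower number from compound 3 to compound 4 (0.15 log units; that floor lies within the scatter), so the data support no claim of a gain beyond the scatter, though the true size of the step may be larger than this floor. The step can be read only as a floor because compound 3 carries a limit of the assay and not a number: the limit of > 100000 nM in this assay, at which 2 of the 4 values shown sit.

As far as these compounds go, it remains open which part of the entering group matters, the sulfur atoms or the six-membered non-aromatic ring with its 2 hetero atoms, since compound 4 carries them together. From the compounds shown here alone, it is also open how a simple amine, a carboxylic acid or a longer sulfur-bearing chain at this same place would read in this assay, and whether any group here could move the number clearly beyond the scatter.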